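Chloro replaces hydroxy-iodo ring on the carbonyl carbon

The source may hold more compounds than are shown below. What is called first, only, known or untested is meant among the compounds shown, and "the series" means these compounds.

Measured compounds in an ADME assay on cells (Macrophage, Mus musculus) for cytotoxicity, read by resazurin assay, with a stated time of 3 days; on this read-out higher numbers stand for weaker inhibition and lower numbers for stronger inhibition:
compound 1 `O=C(Nc1cc(C(F)(F)F)cc(C(F)(F)F)c1)c1cccc(Cl)c1`: > 60000 nM
compound 2 `O=C(Nc1cc(C(F)(F)F)cc(C(F)(F)F)c1)c1cc(F)ccc1O`: 2500 nM
compound 3 `O=C(Nc1cc(C(F)(F)F)cc(C(F)(F)F)c1)c1cc(I)ccc1O`: 5600 nM

The value of compound 1 is a limit of this assay and not a number (the limit of > 60000 nM in this assay, at which 1 of the 3 values shown sits). Within the numbers shown, compound 3 stands highest; its nearest neighbour is compound 2, with a 2.2-fold higher number from compound 2 to compound 3 (0.35 log units; beyond the scatter).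

Compound 4 `O=C(Nc1cc(C(F)(F)F)cc(C(F)(F)F)c1)c1ccccc1Cl` is not yet measured. It differs from compound 3 as follows: 2-chlorophenyl in place of 2-hydroxy-5-iodophenyl on a carbonyl carbon. For the measured compounds named here, two measured steps bear on this change. Replacing 3-chlorophenyl with a 2-hydroxy-substituted ring gave an at least 24-fold lower number from compound 1 to compound 2 (1.38 log units; beyond the scatter) and an at least 10-fold lower number from compound 1 to compound 3 (1.02 log units; beyond the scatter), both large and both beyond the scatter. The step from compound 3 to compound 4 runs the other way, back to a chlorophenyl without the hydroxy group, so a large rise in the number is expected, quite possibly out to the limit of this assay. For compound 4 the estimate is 40000 nM (range 8000 nM to 120000 nM), which means an expected step of a 7.1-fold higher number from compound 3 to compound 4 (0.85 log units; beyond the scatter).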

Compound 4, half-maximal inhibitory concentration: > 1700 nM
Compound 4 gave a limit, no number; the forecaster's own chance of this, stated with the estimate: 55%; the middle value lies beyond the limit too.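

In this assay compound 4 gives a limit and not a number, so no step from compound 1, compound 2 or compound 3 to compound 4 can be read: the limit of > 1700 nM in this assay, at which 1 of the 4 values shown sits.

Still open, from the compounds shown here alone, is how 2-chlorophenyl on the carbonyl carbon compares with 2-hydroxy-5-iodophenyl and 5-fluoro-2-hydroxyphenyl in this assay.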